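Adding a Nitro Group to a Weakly Cytotoxic Anilide

The compounds below may be only part of what the source reports. "The series", "measured", "known", "first", "only" and "open" are said of these compounds alone.

In an ADME assay on HEK293 cells (Homo sapiens) for cytotoxicity, read by MTT assay, with a stated time of 48 h (on this read-out lower numbers stand for stronger inhibition and higher numbers for weaker inhibition), compound 1 `CCS(=O)(=O)Nc1ccc(NC(=O)c2ccc(Cl)c([N+](=O)[O-])c2)cc1OC` gives 63700 nM. Compound 2 `CCS(=O)(=O)Nc1ccc(NC(=O)c2ccc(Cl)cc2)cc1Cl` reaches only a limit of this assay, > 250000 nM, so no number is known for it. This is the limit of > 250000 nM in this assay, at which 1 of the 2 values shown sits, and compound 2 therefore stands at the weak end of what has been seen. Compound 3 `CCS(=O)(=O)Nc1ccc(NC(=O)c2ccc(Cl)c([N+](=O)[O-])c2)cc1Cl` has not yet been measured in this assay. It differs from compound 2 by nitro in place of hydrogen on an aromatic carbon; in words, nitro in place of hydrogen on an aromatic carbon. Going by the values given here, no step between two measured compounds exists here, so the size of this change cannot be read from the data. Compound 3 is expected to give about 120000 nM, between 40000 nM and 300000 nM. The step of an at least 2.0-fold lower number from compound 2 to compound 3 (0.31 log units; beyond the scatter) is expected to be a modest move toward a measurable number, with a real chance that compound 3 is also expected to stay at the limit.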

Compound 3, half-maximal inhibitory concentration: 63800 nM
Estimate against measurement, compound 3: 1.9-fold (0.27 log units) above, and the stated range covers the measured number.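

In this assay, nitro in place of hydrogen on an aromatic carbon, ortho to a chloro group, gives an at least 3.9-fold lower number from compound 2 to compound 3 (0.59 log units; beyond the scatter), which turns a limit into a measurable number. Chloro in place of methoxy on an aromatic carbon gives a 1.0-fold higher number from compound 1 to compound 3 (0.00 log units; within the scatter), so with the nitro group present, compound 1 and compound 3 cannot be told apart here. The full size of the nitro step stays unknown because compound 2 stands at a limit and not at a number: the limit of > 250000 nM in this assay, at which 1 of the 3 values shown sits.

From the compounds shown here alone, whether an amine or a nitrile on that same aromatic carbon would give a similar number remains open. So does the question of whether methoxy and chloro would still match in a compound carrying hydrogen in place of the nitro group.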